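Aminoethyl indene series: chloro to methylsulfanyl at the aromatic carbon

The source may report more compounds than this note shows. Statements on the series, on what has been measured and on what is new or still open speak of the compounds shown alone.

Measured so far:
compound 1 `COc1ccc2c(c1)C(C(C)c1ccccn1)=C(CCN(C)C)C2` 8910 nM
compound 2 `CC(C1=C(CCN(C)C)Cc2ccc(Cl)cc21)c1ccccn1` 912 nM

In an assay on CHO-K1 cells for binding affinity to muscarinic acetylcholine receptor M5 (Homo sapiens) (on this read-out higher numbers stand for weaker inhibition and lower numbers for stronger inhibition), compound 1 gives 8910 nM and compound 2 gives 912 nM. Among the compounds with values here, the only single-point step so far is a 9.8-fold lower number from compound 1 to compound 2 (0.99 log units; beyond the scatter), a change of chloro in place of methoxy on an aromatic carbon. Compound 2 thus stands lowest of the two numbers; its nearest neighbour is compound 1, whose number is higher by the same step.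

Compound 3 `CSc1ccc2c(c1)C(C(C)c1ccccn1)=C(CCN(C)C)C2` is the next member. It differs from compound 2 by methylsulfanyl in place of chloro on an aromatic carbon. Within the data shown here, no measured step involves a methylsulfanyl group, so the one measured step gives only indirect guidance: it shows that this aromatic carbon tolerates a change of substituent with a modest shift in this assay, but it says nothing about sulfur in particular. The expectation therefore rests on the value of compound 2, with a wide range to either side.

For compound 3 the expected step from compound 2 is a 1.6-fold higher number from compound 2 to compound 3 (0.22 log units; within the scatter), not beyond the scatter. Compound 3 is estimated at 1500 nM in this assay, with a range from 400 nM to 6000 nM.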

Compound 3, inhibition constant: 3240 nM
The estimate for compound 3 lay 2.2-fold (0.33 log units) below the measured number, and the stated range covers the measured number.
By their numbers in this assay, from the lowest: compound 2; then compound 3; then compound 1.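

In this assay this aromatic carbon now carries three substituents that can be ranked, with chloro giving the lowest number, methylsulfanyl the middle one and methoxy the highest, and every gap between them lies beyond the scatter. Methylsulfanyl loses part of what chloro gained, with a 3.6-fold higher number from compound 2 to compound 3 (0.55 log units; beyond the scatter), yet it still improves on methoxy, with a 2.8-fold lower number from compound 1 to compound 3 (0.44 log units; beyond the scatter), so the sulfur and oxygen groups are not interchangeable at this position and the earlier single step is now part of a three-member order. No measured evidence on hand accounts for this order.

Still open, from the compounds shown here alone, is whether fluoro, bromo or a nitrile on this aromatic carbon would give a number below that of chloro, and whether a longer thioether such as ethylsulfanyl would stay close to methylsulfanyl. Also open, going by these compounds, is whether the same order of chloro, methylsulfanyl and methoxy holds on the shared core once the pyridine-bearing side chain or the dimethylamino group is replaced, for example by a pyrrolidine.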